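Chain-end change on a shared core: an expected growth number

This account rests on a few compounds, and the source may have more. Where it says the series, first, only, none or still open, it means among the compounds named here.

Measured in a functional assay on A549 cells (Homo sapiens) for antiproliferative activity, read by MTT assay, with a stated time of 48 h; on this read-out higher numbers stand for weaker inhibition of growth and lower numbers for stronger inhibition of growth:
compound 1 `Cc1ccc(-c2cnc(N(Cc3ccccc3)Cc3ccc(C(=O)NO)cc3)s2)cc1` gives 4410 nM
compound 2 `CCCCCCCCN(Cc1ccc(C(=O)NO)cc1)c1ncc(-c2ccc(C)cc2)s1` gives 4630 nM

For the measured compounds named here, compound 2 stands alongside compound 1, the only other measured compound, and the two cannot be told apart: the step of a 1.0-fold higher number from compound 1 to compound 2 (0.02 log units; within the scatter). That step exchanges heptyl for phenyl on the saturated chain carbon bound to the nitrogen on the aromatic ring, and it left the read-out of this assay unchanged within the scatter.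

Compound 3 `Cc1ccc(OCCCCN(Cc2ccc(C(=O)NO)cc2)c2ncc(-c3ccc(C)cc3)s2)cc1` has not yet been measured. It differs from compound 2 by 4-methylphenoxy in place of butyl on a saturated chain carbon, four bonds along the chain from a nitrogen on an aromatic ring. Going by the values given here, the one measured step that bears on this change is the one from compound 1 to compound 2, since it also alters the group carried on the chain at the ring nitrogen, and it was a 1.0-fold higher number from compound 1 to compound 2 (0.02 log units; within the scatter). On that basis, the step from compound 2 to compound 3 is expected to be a 1.0-fold lower number from compound 2 to compound 3 (0.01 log units; within the scatter), with no change beyond the scatter. Compound 3 is therefore estimated at 4500 nM, in a range from 1800 nM to 11000 nM.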

Compound 3, concentration for 50% growth inhibition: 8630 nM
Estimate against measurement, compound 3: 1.9-fold (0.28 log units) below; measured number inside the range.
By their numbers in this assay, from the lowest: compounds 1, 2 and 3 (each within the scatter of the next).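

Replacing butyl with 4-methylphenoxy on a saturated chain carbon, four bonds along the chain from a nitrogen on an aromatic ring, gave a step that stays within the scatter in this assay (a 1.9-fold higher number from compound 2 to compound 3 (0.27 log units; within the scatter)). Compound 3 also cannot be told apart from compound 1, whose phenyl gives way to 3-(4-methylphenoxy)propyl (a 2.0-fold higher number from compound 1 to compound 3 (0.29 log units; within the scatter)). The earlier pair compared only phenyl with heptyl, so this result adds a chain that carries both an oxygen and a six-membered aromatic ring of carbon only, and the three compounds still show no separation in growth inhibition at this position. Nothing given here offers an explanation for these numbers, and the comparison rests on the growth read-out alone.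

The compounds shown leave open whether a chain ending in an amine or a carboxylic acid would give a step beyond the scatter at this position. For the compounds shown here, they also leave open how 4-methylphenoxy would read on a shorter chain or a longer chain than the one in compound 3.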